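The source may hold more compounds than are shown below. What is called first, only, known or untested is meant among the compounds shown, and "the series" means these compounds.

Among the compounds with values here, in an assay on isolated protein for inhibition of kynurenine--oxoglutarate transaminase 1 (Homo sapiens), read by HPLC, with a stated time of 20 min (on this read-out higher numbers stand for weaker inhibition and lower numbers for stronger inhibition), the series so far holds three measured compounds and one that awaits its number. Compound 1 `Cc1ccc2[nH]c(C(=O)O)c(CCC(=O)O)c2c1` is known only as a limit of the assay, not as a number: in this assay compound 1 gives > 1000000 nM. The two other measured compounds are built on a different core. Compound 2 `CCOC(=O)/C(CCCC(=O)O)=N\Nc1ccc(Br)cc1` gives 21000 nM in this assay, and compound 3 `CCOC(=O)/C(CCCC(=O)O)=N\Nc1ccc(C)cc1` gives 33000 nM. Within the data shown here, the single measured step between close neighbours is a 1.6-fold higher number from compound 2 to compound 3 (0.20 log units; within the scatter), a change that stays inside the scatter.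

The step followed here leads from compound 1 to compound 4 `O=C(O)CCc1c(C(=O)O)[nH]c2ccc(Cl)cc12`, which has not yet been measured in this assay. The change is chloro in place of methyl on an aromatic carbon. Among the measured compounds shown here, only one measured step speaks to such an exchange, the replacement of bromo by methyl on an aromatic carbon, which came out as a 1.6-fold higher number from compound 2 to compound 3 (0.20 log units; within the scatter). That step stayed within the scatter, and since compound 1 sits at the limit of > 1000000 nM in this assay, at which 1 of the 3 values shown sits, the exchange of methyl for chloro is expected to yield no step beyond the scatter in either direction. Compound 4 is therefore expected to show a number no higher from compound 1 to compound 4 (the limit leaves the size open), an expected value of 1000000 nM with a range from 300000 nM to 3000000 nM, most likely reported once more only as a limit.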

Compound 4, half-maximal inhibitory concentration: 293000 nM
Estimate against measurement, compound 4: 3.4-fold (0.53 log units) above, and the stated range ends above it.
By their numbers in this assay, from the lowest: compounds 2 and 3 (each within the scatter of the next); then compound 4. At a limit, above all of these: compound 1.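

In this assay, chloro in place of methyl on this aromatic carbon of the six-membered ring brings the core of compound 1 off the limit of the assay and onto a measured number, giving an at least 3.4-fold lower number from compound 1 to compound 4 (0.53 log units; beyond the scatter). Within the data shown here, the only earlier exchange on an aromatic carbon, methyl in place of bromo, gave a 1.6-fold higher number from compound 2 to compound 3 (0.20 log units; within the scatter) and could not be told from the scatter, whereas this exchange on the core of compound 1 shows a real difference, with the number lower on the side carrying the halogen. How large the step truly is cannot be read, and it is known only as a lower bound because the starting point is a limit of the assay and not a number: the limit of > 1000000 nM in this assay, at which 1 of the 4 values shown sits.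

The compounds shown leave open whether bromo, methoxy or an amine on the same aromatic carbon of the core of compound 1 would bring the number lower than chloro does. They also do not tell whether a longer chain carrying the carboxylic acid would move the number of compound 4 in either direction.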